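Removing the tosyl group from a triazole-bearing phenol core

A few compounds are considered here, and "the series" means these few. Any claim that something is new, unique, unknown or untested is made for them only; others in the source may bear on it.

Compound 1 `C=C1C[C@]23C[C@@]1(O)CC[C@H]2c1ccc(OS(=O)(=O)c2ccc(C)cc2)c(C)c1[C@@H]3Cn1cc(-c2ccc(Cl)cc2)nn1`: in a functional assay on A549 cells (Homo sapiens) for cytotoxicity, read by MTT assay, with a stated time of 4 days (a higher number here means a weaker inhibitor, a lower number a stronger inhibitor), compound 1 gives > 20000 nM, which is a limit of the assay.
Compound 2 `C=C1C[C@]23C[C@@]1(O)CC[C@H]2c1ccc(OS(=O)(=O)c2ccc(C)cc2)c(C)c1[C@@H]3Cn1cc(-c2ccc(OC)cc2)nn1`: in this assay compound 2 gives > 20000 nM, again a limit.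
Compound 3 `C=C1C[C@]23C[C@@]1(O)CC[C@H]2c1ccc(OS(=O)(=O)c2ccc(C)cc2)c(C)c1[C@@H]3Cn1cc(-c2ccccc2)nn1`: in this assay compound 3 gives > 20000 nM, also a limit.

Compound 1 therefore stands at the same limit as the other two measured compounds; none of the three gives a number, a situation summed up by the limit of > 20000 nM in this assay, at which 3 of the 3 values shown sit. The measured steps, a step that the two limits leave unreadable from compound 1 to compound 2, a step that the two limits leave unreadable from compound 1 to compound 3 and a step that the two limits leave unreadable from compound 2 to compound 3, all change the substituent on the phenyl ring of the triazole, and each is unreadable because both ends sit at the limit.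

Compound 4 `C=C1C[C@]23C[C@@]1(O)CC[C@H]2c1ccc(O)c(C)c1[C@@H]3Cn1cc(-c2ccc(Cl)cc2)nn1` differs from compound 1 in another part of the molecule: hydrogen in place of (4-methylphenyl)sulfonyl on an oxygen on an aromatic ring. No measured step touches this position, so nothing shown bears directly on it. With compound 1 itself only known as a limit, the step expected in this assay from compound 1 to compound 4 is a number no higher from compound 1 to compound 4 (the limit leaves the size open), in no direction that the data can support. Compound 4 is therefore expected to give about 20000 nM in this assay, with a range of 4000 nM to 60000 nM, and a substantial chance that only a limit is reported again.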

Compound 4, half-maximal inhibitory concentration: > 20000 nM
Compound 4 gave a limit, no number (the forecaster's own chance of this, stated with the estimate: 55%); the middle value lies on the limit itself.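

In this assay compound 4 gives > 20000 nM, which is a limit of the assay. Within the data shown here, no step from compound 1 to compound 4 can be read, because both compounds sit at the same limit: the limit of > 20000 nM in this assay, at which 4 of the 4 values shown sit. The compounds shown leave open how far the activity of any of them lies beyond that limit, and whether either changed position affects it.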